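This account rests on a few compounds, and the source may have more. Where it says the series, first, only, none or still open, it means among the compounds named here.

In an ADME assay on H9 cells (Homo sapiens) for cytotoxicity, read by XTT assay, with a stated time of 6 days (on this read-out higher numbers stand for lower toxicity in this test and lower numbers for higher toxicity in this test), compound 1 (`Cc1cccc(C)c1Oc1ccc([N+](=O)[O-])c(Nc2ccc(C#N)cc2)c1`) gives 69600 nM and compound 2 (`Cc1cc(C)c(Oc2ccc(N)c(Nc3ccc(C#N)cc3)c2)c(C)c1`) gives 51000 nM. Among the measured compounds shown here, these two values lie within the scatter of each other, so compound 2 stands level with compound 1 on the numbers so far.

Compound 3 (`Cc1cc(C)c(Oc2ccc([N+](=O)[O-])c(Nc3ccc(C#N)cc3)c2)c(C)c1`) has nitro in place of amino on an aromatic carbon of compound 2: nitro in place of amino on an aromatic carbon. For the measured compounds named here, no measured step between compounds that differ in one place is available, so the size of this change rests on two values only. Compound 1, which also carries a nitro group, gives 69600 nM. The expected change is small and upward, a 1.1-fold higher number from compound 2 to compound 3 (0.06 log units; within the scatter), with no shift beyond the scatter of this assay anticipated. For compound 3 the estimated value is 58000 nM, with an expected range of 27000 nM to 120000 nM.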

Compound 3, half-maximal cytotoxic concentration: > 67000 nM
Compound 3: a limit, no number; the forecaster's own chance of this, stated with the estimate: 15%; middle value at least 1.1-fold (0.06 log units) away from the limit.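

In this assay compound 3 gives > 67000 nM, a limit of the assay and not a number: the limit of > 67000 nM in this assay, at which 1 of the 3 values shown sits. Nitro in place of amino on an aromatic carbon, para to a large group and ortho to a group of 9 heavy atoms, gives an at least 1.3-fold higher number from compound 2 to compound 3 (0.11 log units; that floor lies within the scatter), so this change has a floor but no measured size, and nothing beyond the scatter is shown at this position. The step for methyl in place of hydrogen on an aromatic carbon, from compound 1 to compound 3, cannot be read.

On these data alone, how far the value of compound 3 lies past its limit stays open, and with it the full size of the change from amino to nitro. Also open, as far as these compounds go, is how a carboxylic acid or an amide at this position would read in this assay.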